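The source may hold more compounds than are shown below. What is called first, only, known or untested is meant among the compounds shown, and "the series" means these compounds.

Compound 2 `O=C(O)CCc1cc(-c2cccnc2)cc2c1CCC(NS(=O)(=O)c1ccc(Cl)cc1)C2` is tested in an assay on blood with Thromboxane-A synthase (Homo sapiens) as the target (a lower number here means a stronger inhibitor, a higher number a weaker inhibitor), and gives only a limit of the assay there, > 5000 nM. Compound 1 `O=C(O)CCc1c(-c2cccnc2)ccc2c1CCC(NS(=O)(=O)c1ccc(Cl)cc1)C2` also gives only a limit in this assay, > 10000 nM. Both values thus sit at limits, as noted in the limit of > 10000 nM in this assay, at which 1 of the 2 values shown sits, and (the limit of > 5000 nM in this assay, at which 1 of the 2 values shown sits), so the true strength of either compound is not known. Compound 3 `O=C(O)CCc1cc(Cc2cccnc2)cc2c1CCC(NS(=O)(=O)c1ccc(Cl)cc1)C2` differs from compound 2 by (pyridin-3-yl)methyl in place of pyridin-3-yl on an aromatic carbon. Among the compounds with values here, with no measured step of this kind to lean on, no direction can be read off. Compound 3 is expected to give about 5000 nM in this assay, in a range from 1000 nM to 20000 nM, which would mean a step of a number no higher from compound 2 to compound 3 (the limit leaves the size open).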

Compound 3, half-maximal inhibitory concentration: 1100 nM
Compound 3: middle estimate off by 4.5-fold (0.66 log units), on the high side; low and high end bracket the measured number.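

In this assay, within the data shown here, compound 3 gives 1100 nM, the only value shown that is not a limit. On this aromatic carbon, (pyridin-3-yl)methyl in place of pyridin-3-yl gives an at least 4.5-fold lower number from compound 2 to compound 3 (0.65 log units; beyond the scatter). Compound 2 gives only a limit, so the full size of this step stays unknown: the limit of > 5000 nM in this assay, at which 1 of the 3 values shown sits.

From the compounds shown here alone, whether pyridin-3-yl on a longer chain would lower the number further stays open. So does whether (pyridin-3-yl)methyl would give a similar step on the aromatic carbon that carries pyridin-3-yl in compound 1.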